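Trading a pyrrole ring for an amino group on the core

The source may hold more compounds than are shown below. What is called first, only, known or untested is meant among the compounds shown, and "the series" means these compounds.

Measured so far:
- compound 1, `Cc1nn(C)cc1Nc1nc(N)c2c(C#N)c(N3CCC[C@H]3C)n(C)c2n1`: 2 nM
- compound 2, `Cn1c(-n2cccc2)c(C#N)c2c(N)ncnc21`: 1980 nM
- compound 3, `C[C@@H]1CCCN1c1c(C(N)=O)c2c(N)ncnc2n1C`: 154 nM

In an assay on isolated protein for binding affinity to Leucine-rich repeat serine/threonine-protein kinase 2 variant G2019S (Homo sapiens), read by TR-FRET and LanthaScreen, with a stated time of 2 h (a higher number here means a weaker inhibitor, a lower number a stronger inhibitor), compound 2 gives 1980 nM. This is the highest of the three numbers, so compound 2 is the weakest binder here. Compound 3 sits closer to it with 154 nM, and compound 1 is the furthest away with 2 nM; both gaps to compound 2 are beyond the usual scatter.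

Compound 4, `Cn1c(N)c(C#N)c2c(N)ncnc21`, has not been measured. It differs from compound 2 in one place: amino in place of 1H-pyrrol-1-yl on an aromatic carbon

Within the data shown here, no measured pair shows this change on its own, so there is no directly comparable step. The other two compounds carry a larger saturated ring at the same place, and only compound 1 pairs that with a further substituent on the core. With a small amino group instead of a ring, a modest loss is expected, with the step of a 1.5-fold higher number from compound 2 to compound 4 (0.18 log units; within the scatter) possibly not exceeding the scatter. Compound 4 is expected to give about 3000 nM, within a range of 800 nM to 12000 nM.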

Compound 4, inhibition constant: 589 nM
Beside the measured number, compound 4's estimate is 5.1-fold (0.71 log units) above it; the measured number lies below the stated range.
By their numbers in this assay, from the lowest: compound 1; then compound 3; then compound 4; then compound 2.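

In this assay, among these compounds, replacing the 1H-pyrrol-1-yl ring with amino on this aromatic carbon gives a 3.4-fold lower number from compound 2 to compound 4 (0.53 log units; beyond the scatter) and is the first change at this position seen on its own. It shows that binding here does not depend on keeping a five-membered aromatic ring, since the single-atom amino group gives the stronger binder of this pair. No measurement shown explains this gain.

The compounds shown leave open how other small groups on this carbon, such as methyl or dimethylamino, would compare with amino. Also open, as far as these compounds go, is what the saturated methyl-bearing ring of compound 3 would do on this carbon with the nitrile kept and the rest of compound 4 unchanged, as neither compound 1 nor compound 3 differs from compound 4 in this one place alone.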